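Amide in place of methoxy on the shared core

A few compounds are considered here, and "the series" means these few. Any claim that something is new, unique, unknown or untested is made for them only; others in the source may bear on it.

The three measured compounds share the core of compound 1 `O=[N+]([O-])c1ccc(-c2nc3cc(C(F)(F)F)ccc3[nH]2)cc1` and differ only in the group on the phenyl ring. In an ADME assay on BHK cells (Mesocricetus auratus) for cytotoxicity, read by MTT assay, with a stated time of 96 h (a higher number here means that more compound is tolerated, a lower number that less compound is tolerated), compound 1 gives 18000 nM. Compound 2 `CCC(=O)Nc1ccc(-c2nc3cc(C(F)(F)F)ccc3[nH]2)cc1` carries a propanoylamino group instead and gives 100000 nM in this assay, a step of a 5.6-fold higher number from compound 1 to compound 2 (0.74 log units; beyond the scatter). Compound 3 `COc1ccc(-c2nc3cc(C(F)(F)F)ccc3[nH]2)cc1` carries a methoxy group. For compound 3 the result in this assay is only a limit, > 100000 nM, and compound 3 therefore stands at or beyond the top of the numbers seen so far. The step from nitro to methoxy is an at least 5.5-fold higher number from compound 1 to compound 3 (0.74 log units; beyond the scatter), and a number no lower from compound 2 to compound 3 (the limit leaves the size open).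

Compound 4 `CCN(CC)CC(=O)Nc1ccc(-c2nc3cc(C(F)(F)F)ccc3[nH]2)cc1` is the next compound, differing from compound 3 in this way: (((diethylamino)methyl)carbonyl)amino in place of methoxy on an aromatic carbon. Compound 4 shares the amide linkage of compound 2, which gives 100000 nM in this assay. The step of a number no lower from compound 2 to compound 3 (the limit leaves the size open) gives no readable size, so no change beyond the scatter is expected from compound 3 to compound 4. Compound 4 is expected to give 80000 nM in this assay, within 25000 nM to 200000 nM, which means an expected step of an at least 1.2-fold lower number from compound 3 to compound 4 (0.09 log units; that floor lies within the scatter).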

Compound 4, half-maximal cytotoxic concentration: 23000 nM
Beside the measured number, compound 4's estimate is 3.5-fold (0.54 log units) above it; the measured number lies below the stated range.
By their numbers in this assay, from the lowest: compounds 1 and 4 (each within the scatter of the next); then compound 2.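

In this assay, diethylamino in place of methyl on the saturated chain carbon bound to the carbonyl carbon gives a 4.3-fold lower number from compound 2 to compound 4 (0.64 log units; beyond the scatter), so sharing the amide linkage does not keep a compound at the level of compound 2. Against methoxy, the change gives an at least 4.3-fold lower number from compound 3 to compound 4 (0.63 log units; beyond the scatter), and that size is only a floor, since compound 3 is known only as a limit: the limit of > 100000 nM in this assay, at which 1 of the 4 values shown sits. Against nitro, the change gives a 1.3-fold higher number from compound 1 to compound 4 (0.11 log units; within the scatter), so this assay does not separate those two groups.

On these data alone, whether the lower number belongs to the diethylamino group in particular or to any amine on this chain stays open; a dimethylamino group, a piperidine ring or a longer chain carrying the amine could tell these apart. As far as these compounds go, how far compound 3 lies beyond its limit also stays open.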